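A Sulfamoyl Group Where Cyano Once Cost Potency

The source may hold more compounds than are shown below. What is called first, only, known or untested is meant among the compounds shown, and "the series" means these compounds.

Compound 1 `Cc1cccc(NNS(=O)(=O)c2ccc(C#N)cc2)c1`: 59 nM
Compound 2 `CC(=O)Nc1ccc(S(=O)(=O)NNc2ccccc2)cc1`: 71 nM
Compound 3 `CC(=O)Nc1ccc(S(=O)(=O)NNc2ccc(C#N)cc2)cc1`: 5670 nM

These three compounds were measured in an assay for inhibition of Indoleamine 2,3-dioxygenase 1 (Homo sapiens), read by spectrophotometry, with stated times of 1 h and 4 h; a higher number here means a weaker inhibitor, a lower number a stronger inhibitor. Compound 2 stands second highest of the three numbers; compound 1 lies within the usual scatter of it, whereas compound 3 is far higher, and so a much weaker inhibitor. The unmeasured compound 4 `CC(=O)Nc1ccc(S(=O)(=O)NNc2ccc(S(N)(=O)=O)cc2)cc1` differs from compound 2 by sulfamoyl in place of hydrogen on an aromatic carbon. For the measured compounds named here, only one measured step bears on this change: an 80-fold higher number from compound 2 to compound 3 (1.90 log units; beyond the scatter), where a cyano group entered on the same aromatic carbon. Sulfamoyl is a different group, so the outcome is uncertain, but a weakening step of similar direction is expected. Compound 4 is estimated at 1500 nM, within 200 nM to 9000 nM, which means an expected step of a 21-fold higher number from compound 2 to compound 4 (1.32 log units; beyond the scatter).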

Compound 4, half-maximal inhibitory concentration: 2480 nM
Beside the measured number, compound 4's estimate is 1.7-fold (0.22 log units) below it; the range from low to high includes it.
By their numbers in this assay, from the lowest: compounds 1 and 2 (each within the scatter of the next); then compound 4; then compound 3.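

Sulfamoyl on this aromatic carbon brings a 35-fold higher number from compound 2 to compound 4 (1.54 log units; beyond the scatter) and so, like cyano, costs much of the potency of compound 2, which means the loss is not peculiar to cyano. The two groups still differ at this place, with a 2.3-fold lower number from compound 3 to compound 4 (0.36 log units; beyond the scatter) as a modest step that is beyond the scatter. Nothing available explains either loss. Going by these compounds, whether any group here can match hydrogen remains open. An amine or a carboxylic acid on this carbon might keep the number low or raise it just as far.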